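A few compounds are considered here, and "the series" means these few. Any claim that something is new, unique, unknown or untested is made for them only; others in the source may bear on it.

Compound 1 `COc1cc(NC(C)CCCNC(=O)Nc2ccc(Br)cc2)c2ncccc2c1`: 23000 nM
Compound 2 `COc1cc(NC(C)CCCNC(=O)NNC(=O)Nc2ccc(F)cc2)c2ncccc2c1`: > 100000 nM
Compound 3 `COc1cc(NC(C)CCCNC(=O)NNC(=O)Nc2ccc(C(F)(F)F)cc2)c2ncccc2c1`: 12000 nM

All three values come from a functional assay on SW-620 cells (Homo sapiens) for inhibition, read by MTT assay, with a stated time of 72 h; on this read-out higher numbers stand for weaker inhibition and lower numbers for stronger inhibition. Compound 2 gives > 100000 nM, which is a limit of the assay and not a number. Going by the values given here, the series thus holds (the limit of > 100000 nM in this assay, at which 1 of the 3 values shown sits), and compound 2 is the one compound sitting there.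

The next compound, compound 4 `COc1cc(NC(C)CCCNC(=O)Nc2cccc(O)c2)c2ncccc2c1`, has not yet been measured. It differs from compound 2 as follows: 3-hydroxyphenyl in place of ((4-fluorophenyl)carbamoyl)amino on an amide-type nitrogen. In words, 3-hydroxyphenyl stands in place of ((4-fluorophenyl)carbamoyl)amino on an amide-type nitrogen.

Among the compounds with values here, two measured steps bear on this. The closer one is an at least 4.3-fold higher number from compound 1 to compound 2 (0.63 log units; beyond the scatter), an exchange at the same place, where compound 1 carries 4-bromophenyl. Compound 4 also loses the ((4-fluorophenyl)carbamoyl)amino group, so it should resemble compound 1 more than compound 2. The other is an at least 8.3-fold lower number from compound 2 to compound 3 (0.92 log units; beyond the scatter), which shows that an exchange on the aromatic ring alone can shift the number by a similar size. How 3-hydroxyphenyl compares with 4-bromophenyl is unmeasured, so the range must stay wide.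

In this assay, the expected change is a move to a lower number, an at least 2.8-fold lower number from compound 2 to compound 4 (0.45 log units; beyond the scatter). For compound 4 the estimated value is 35000 nM, with an expected range of 12000 nM to 100000 nM.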

Compound 4, half-maximal inhibitory concentration: 27000 nM
The estimate for compound 4 lay 1.3-fold (0.11 log units) above the measured number; the range from low to high includes it.
By their numbers in this assay, from the lowest: compounds 3, 1 and 4 (each within the scatter of the next, the first and the last beyond it). At a limit, above all of these: compound 2.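

In this assay, the new result tests a second group at the same place, on an amide-type nitrogen whose other neighbour is a carbonyl carbon, and 3-hydroxyphenyl in place of ((4-fluorophenyl)carbamoyl)amino gives an at least 3.7-fold lower number from compound 2 to compound 4 (0.56 log units; beyond the scatter). Going by these compounds alone, compound 4 is also the first direct comparison of two phenyl groups bound straight to this nitrogen, and the step to it is a 1.2-fold higher number from compound 1 to compound 4 (0.07 log units; within the scatter), so 3-hydroxyphenyl and 4-bromophenyl cannot be told apart in this assay, although they carry different groups on the ring. From the compounds shown here alone, the step from compound 2 therefore shows that two different phenyl groups at this place both read differently from the ((4-fluorophenyl)carbamoyl)amino group, but its true size stays unknown, as compound 2 gives only a limit and not a number: the limit of > 100000 nM in this assay, at which 1 of the 4 values shown sits.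

The compounds shown leave open whether any group on the phenyl ring matters at all when that ring sits directly on this nitrogen, and an amine or a carboxylic acid on the ring would help to test this. Within the data shown here, they also leave open how trifluoromethyl would behave there, since its only value here belongs to compound 3, which carries the longer chain.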